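Swapping the fluoro-methoxyphenyl arm for a dimethylphenyl arm

The source may hold more compounds than are shown below. What is called first, only, known or untested is meant among the compounds shown, and "the series" means these compounds.

Measured compounds in a functional assay on B16-F0 cells (Mus musculus) for inhibition, read by CCK-8 assay, with a stated time of 48 h; on this read-out lower numbers stand for stronger inhibition and higher numbers for weaker inhibition:
Compound 1 `COc1ccc(-c2cc3nccc(-c4cc(OC)c(OC)c(OC)c4)n3n2)cc1[N+](=O)[O-]` gives > 10000 nM, a limit of the assay rather than a number.
Compound 2 `COc1cc(-c2cc3nccc(-c4c[nH]c5ccccc45)n3n2)cc(OC)c1OC` gives > 10000 nM, likewise a limit.
Compound 3 `COc1ccc(-c2cc3nccc(-c4cc(OC)c(OC)c(OC)c4)n3n2)cc1F` gives 3950 nM.

Within the data shown here, compound 3 is thus the only compound of the three with a measured number; the other two sit at the limit of > 10000 nM in this assay, at which 2 of the 3 values shown sit. Among the measured compounds shown here, the one measured step, an at least 2.5-fold lower number from compound 1 to compound 3 (0.40 log units; beyond the scatter), comes from fluoro in place of nitro on an aromatic carbon and shows that a change on this arm of the shared core can move the read-out past the scatter.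

Compound 4 `COc1cc(-c2ccnc3cc(-c4ccc(C)c(C)c4)nn23)cc(OC)c1OC` has not been measured. It differs from compound 3 by 3,4-dimethylphenyl in place of 3-fluoro-4-methoxyphenyl on an aromatic carbon. For the measured compounds named here, no measured step changes this arm in the same way, so the step from fluoro to methyl and from methoxy to methyl has no direct precedent here; the only guidance is that compound 3 gave a number while compounds 1 and 2 did not. The expected step of a 1.1-fold lower number from compound 3 to compound 4 (0.05 log units; within the scatter) is therefore small, with the range kept wide on both sides. Compound 4 is estimated at 3500 nM in this assay, between 900 nM and 12000 nM, with a real chance that only a limit is returned.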

Compound 4, half-maximal inhibitory concentration: 391 nM
Beside the measured number, compound 4's estimate is 9.0-fold (0.95 log units) above it; measured number below the stated range.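

In this assay, the change to 3,4-dimethylphenyl on this aromatic carbon of the five-membered ring gives a 10-fold lower number from compound 3 to compound 4 (1.00 log units; beyond the scatter), a step read between two actual numbers. The earlier step on this arm, an at least 2.5-fold lower number from compound 1 to compound 3 (0.40 log units; beyond the scatter), has a limit at one end, so it fixed only a minimum size, whereas this one shows how far the read-out moves between two groups that both return a number. The entering arm counts no hydrogen-bond acceptor, so an acceptor on this arm is not required for compound 4 to give a number rather than a limit, in a set where the limit remains common: the limit of > 10000 nM in this assay, at which 2 of the 4 values shown sit.

Because fluoro and methoxy leave together and two methyl groups enter together, the compounds shown do not separate the contribution of either site on the arm. Also open, going by these compounds, is whether a single methyl, a chloro group, a trifluoromethyl group, an amine or a carboxylic acid on this arm would keep, improve or lose the number seen for compound 4.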